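The source may hold more compounds than are shown below. What is called first, only, known or untested is meant among the compounds shown, and "the series" means these compounds.

Measured compounds:

Compound 1, `CCOC(=O)c1c(-c2cccc(OC)c2)[nH]c2cc(OC)ccc2c1=O`, gives in an ADME assay on Raji cells (Homo sapiens) for cytotoxicity, read by luminescence, with a stated time of 72 h (a lower number here means that less compound is needed, a higher number that more compound is needed for the effect), a value of > 21500 nM, which is a limit of the assay.
Compound 2, `CCOC(=O)c1c(-c2cccc(OC)c2)[nH]c2cc(OC(F)(F)F)ccc2c1=O`, gives in this assay a value of > 21500 nM, again a limit.
Compound 3, `CCOC(=O)c1c(-c2cccc(OC)c2)[nH]c2cc(C(F)(F)F)ccc2c1=O`, gives in this assay a value of > 21500 nM, again a limit.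

All three measured compounds therefore sit at the limit of > 21500 nM in this assay, at which 3 of the 3 values shown sit, and no number was reached for any of them. The change from compound 1 to compound 2 is trifluoromethyl in place of methyl on an oxygen on an aromatic ring. Its step, a step that the two limits leave unreadable from compound 1 to compound 2, cannot be read, as both ends are limits. The cores of compound 1 and compound 3 differ by trifluoromethyl in place of methoxy on an aromatic carbon; the corresponding step that the two limits leave unreadable from compound 1 to compound 3 is likewise unreadable, as is a step that the two limits leave unreadable from compound 2 to compound 3.

Compound 4, `CCOC(=O)c1c(-c2cccc(OC(F)(F)F)c2)[nH]c2cc(C(F)(F)F)ccc2c1=O`, has not yet been measured in this assay. It differs from compound 3 by trifluoromethyl in place of methyl on an oxygen on an aromatic ring, and the place of this change is word for word the same as in the change from compound 1 to compound 2, so it is the same change carried onto the core of compound 3. The earlier instance of this change gave no readable step, and every value shown rests at the same limit, so the expectation for compound 4 is built only on that: the step that the limit leaves unreadable from compound 3 to compound 4 is expected to be small or not readable, and compound 4 is estimated at 30000 nM in this assay, most likely reported again only as a limit, with a range from 15000 nM to 100000 nM.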

Compound 4, half-maximal effective concentration: > 21500 nM
Compound 4 was reported as a limit; the forecaster's own chance of this, stated with the estimate: 85%; the middle value lies beyond the limit too.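

In this assay compound 4 gives > 21500 nM, again a limit of the assay. The change from compound 3 to compound 4, methoxy to trifluoromethoxy, therefore yields no readable step, because both compounds rest at the same limit: the limit of > 21500 nM in this assay, at which 4 of the 4 values shown sit. The compounds shown leave open what size this change has in this assay, and whether any change on the shared core would give a value that is a number rather than a limit.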